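The compounds below may be only part of what the source reports. "The series", "measured", "known", "first", "only" and "open" are said of these compounds alone.

Compounds measured so far: compound 1 `Cc1ccccc1Nc1nc(Nc2ccccc2)ncc1Cl` and compound 2 `CN1CCN(c2ccc(Nc3ncc(Cl)c(NCc4ccc(C(F)(F)F)cc4)n3)nc2)CC1`. In a functional assay on MDA-MB-231 cells (Homo sapiens) for inhibition, read by CCK-8 assay, with a stated time of 48 h (on this read-out lower numbers stand for stronger inhibition of growth and higher numbers for weaker inhibition of growth), compound 1 gives > 100000 nM, which is a limit of the assay and not a number. In this assay compound 2 gives 19100 nM. Compound 2 therefore holds the only number shown; the other value sits at the limit of > 100000 nM in this assay, at which 1 of the 2 values shown sits. Compound 3 `COc1cccc(Nc2nc(Nc3ccc(N4CCN(C)CC4)cn3)ncc2Cl)c1` differs from compound 2 by 3-methoxyphenyl in place of 4-(trifluoromethyl)benzyl on a nitrogen on an aromatic ring. For the measured compounds named here, no measured pair shows this change, so the expected step of a 1.0-fold higher number from compound 2 to compound 3 (0.02 log units; within the scatter) is taken as modest and within the usual scatter. Compound 3 is estimated at 20000 nM, between 4000 nM and 100000 nM.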

Compound 3, concentration for 50% growth inhibition: 8510 nM
For compound 3 the middle estimate is 2.4-fold (0.37 log units) above the measured one; the measured number falls inside the stated range.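

Placing 3-methoxyphenyl in place of 4-(trifluoromethyl)benzyl on a nitrogen on an aromatic ring gives a 2.2-fold lower number from compound 2 to compound 3 (0.35 log units; beyond the scatter) in this assay and so shows that a single change at this position can move the number beyond the scatter. The entering group carries one hydrogen-bond acceptor and the leaving group none, but nothing shown ties the step to this or any other difference. Going by these compounds, it remains open whether the step belongs to the methoxy group or to the shorter link to the ring, and how an amine or a carboxylic acid on the phenyl ring would read.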